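Cytotoxicity in the sulfamide series: fluoro removal, compound 3 to 4

A few compounds are considered here, and "the series" means these few. Any claim that something is new, unique, unknown or untested is made for them only; others in the source may bear on it.

Measured so far in an ADME assay on MT4 cells (Homo sapiens) for cytotoxicity, read by MTT assay, with a stated time of 5 days; a higher number here means that more compound is tolerated, a lower number that less compound is tolerated:
Compound 1, `C=CCN1C(=O)N(Cc2ccccc2)S(=O)(=O)n2cccc21`: gives > 802000 nM, a limit of the assay.
Compound 2, `N#Cc1ccccc1CN1C(=O)N(Cc2ccccc2)S(=O)(=O)n2cccc21`: gives > 318000 nM, a limit of the assay.
Compound 3, `O=C1N(Cc2ccc(Cl)cc2Cl)c2cccn2S(=O)(=O)N1Cc1cccc(F)c1`: gives > 249000 nM, a limit of the assay.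

Compound 3 thus stands at the limit of > 249000 nM in this assay, at which 1 of the 3 values shown sits, with no number of its own; all three measured values are limits. Compound 4 is `O=C1N(Cc2ccc(Cl)cc2Cl)c2cccn2S(=O)(=O)N1Cc1ccccc1`. Its change from compound 3 is hydrogen in place of fluoro on an aromatic carbon. Going by the values given here, the only measured step, a step that the two limits leave unreadable from compound 1 to compound 2, is unreadable, so no step of known size bears on this change, and no change beyond the scatter is expected. Compound 4 is expected to give 250000 nM in this assay, within 100000 nM to 1000000 nM. The expected step that the limit leaves unreadable from compound 3 to compound 4 is therefore none beyond the scatter, most likely again a limit.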

Compound 4, half-maximal cytotoxic concentration: 218000 nM
For compound 4 the middle estimate is 1.1-fold (0.06 log units) above the measured one; measured number inside the range.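

In this assay, going by these compounds alone, compound 4 gives the first reading of the series that is not a limit (218000 nM). The change from 3-fluorobenzyl to benzyl can now be bounded on one side: an at least 1.1-fold lower number from compound 3 to compound 4 (0.05 log units; that floor lies within the scatter) stands for it. On the chain carbon bound to the amide-type nitrogen, the other two comparisons give an at least 1.4-fold lower number from compound 2 to compound 4 (0.16 log units; that floor lies within the scatter) and an at least 3.6-fold lower number from compound 1 to compound 4 (0.56 log units; beyond the scatter) and only the second clears the scatter. The reading for compound 3 remains a limit: the limit of > 249000 nM in this assay, at which 1 of the 4 values shown sits.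

Going by these compounds, the true size of the fluoro step therefore stays open. Also open, on these data alone, is how this assay responds to an amine or a carboxylic acid at that ring carbon.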